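This account rests on a few compounds, and the source may have more. Where it says the series, first, only, none or still open, it means among the compounds named here.

Measured so far, in an ADME assay on THP-1 cells (Homo sapiens) for inhibition, read by MTT assay, with a stated time of 72 h; on this read-out higher numbers stand for weaker inhibition of growth and lower numbers for stronger inhibition of growth:

Compound 1 `Cc1ccc2oc(-c3cc4ccccc4s3)cc(=O)c2c1`: > 100 ug/mL, which is a limit of the assay and not a number.
Compound 2 `O=C(CC(=O)c1ccccc1O)c1cc2ccccc2s1`: > 100 ug/mL, again a limit of the assay rather than a number.

Compound 2 therefore stands at the edge of what this assay can report, and the evidence shows only that (the limit of > 100 ug/mL in this assay, at which 2 of the 2 values shown sit). Within the data shown here, no step between two measured compounds is available, so nothing here tells how any single structural change shifts the read-out.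

Compound 3 `O=C(CC(=O)c1cc(Cl)ccc1O)c1cc2ccccc2s1` differs from compound 2 by one change: chloro in place of hydrogen on an aromatic carbon. With only limits to go on, no step beyond the usual scatter is expected in this assay , in either direction.

On that basis compound 3 is estimated at 100 ug/mL, with a likely range from 40 ug/mL to 250 ug/mL. This estimate corresponds to an expected step of a number no higher from compound 2 to compound 3 (the limit leaves the size open), and it is quite possible that the assay again reports only a limit.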

Compound 3, concentration for 50% growth inhibition: 7.48 ug/mL
Estimate against measurement, compound 3: 13-fold (1.13 log units) above, and the stated range ends above it.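

In this assay, among these compounds, chloro in place of hydrogen on an aromatic carbon gives an at least 13-fold lower number from compound 2 to compound 3 (1.12 log units; beyond the scatter), the first single change that can be read, and it lies beyond the usual scatter. It shows that this position, para to a hydroxy group, can matter a great deal: one added chlorine atom is enough to bring a number into the measurable range of the assay. The true size of the step cannot be given, and the printed size is only a minimum: the limit of > 100 ug/mL in this assay, at which 2 of the 3 values shown sit.

From the compounds shown here alone, whether a bromo, a methoxy or an amine at this same carbon would give a similar step remains open. So does whether chloro on another carbon of this ring, or on the core of compound 1, would have any comparable effect.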